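The source may report more compounds than this note shows. Statements on the series, on what has been measured and on what is new or still open speak of the compounds shown alone.

Compound 1 `Cc1c(OC[C@@H](C)COc2ccc(C(=O)O)cc2F)ccc(C(=O)CC(C)(C)C)c1O` gives, in an assay for positive allosteric modulation of metabotropic glutamate receptor 2 (Rattus norvegicus) (a lower number here means that less compound is needed, a higher number that more compound is needed for the effect), a half-maximal effective concentration of 222 nM. Among the measured compounds shown here, compound 2 `Cc1c(OC[C@@H](C)COc2ccc(C(=O)O)cc2Cl)ccc(C(=O)CC(C)(C)C)c1O` gives 477 nM in this assay, and the only step measured so far, a 2.1-fold higher number from compound 1 to compound 2 (0.33 log units; beyond the scatter), is a modest rise that lies beyond the scatter. For the measured compounds named here, compound 2 therefore stands at the higher of the two numbers known.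

Compound 3 `Cc1c(OC[C@@H](C)COc2ccc(C(=O)O)c(Cl)c2)ccc(C(=O)CC(C)(C)C)c1O` keeps every atom of compound 2 and changes only where the chlorine sits: 4-carboxy-3-chlorophenyl in place of 4-carboxy-2-chlorophenyl on an oxygen on a saturated carbon. Going by the values given here, the step from compound 1 to compound 2 touches the same ring but swaps one halogen for another; no measured step moves a halogen around that ring. Among the compounds with values here, the only guide is that the single measured change on this ring, a 2.1-fold higher number from compound 1 to compound 2 (0.33 log units; beyond the scatter), was modest, so the expected step of a 1.0-fold higher number from compound 2 to compound 3 (0.02 log units; within the scatter) is taken as no change beyond the scatter. Compound 3 is thus estimated at 500 nM, with a range from 200 nM to 1300 nM.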

Compound 3, half-maximal effective concentration: 50 nM
Compound 3: the middle estimate sits 10-fold (1.00 log units) above what was measured; measured number below the stated range.
By their numbers in this assay, from the lowest: compound 3; then compound 1; then compound 2.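

In this assay, the place of the chlorine on the ring counts for more than the earlier halogen swap suggested: with the same atoms joined differently, 4-carboxy-3-chlorophenyl in place of 4-carboxy-2-chlorophenyl gives a 9.5-fold lower number from compound 2 to compound 3 (0.98 log units; beyond the scatter), a larger step than the one seen for chloro in place of fluoro. The chlorine as such does not go with the higher number, since the 4-carboxy-3-chlorophenyl group also beats the 4-carboxy-2-fluorophenyl group, with a 4.4-fold lower number from compound 1 to compound 3 (0.65 log units; beyond the scatter), and compound 3, which carries chlorine, now has the lowest number of the three, with both of its steps beyond the scatter. No measurement shown here explains why moving the chlorine has so large an effect on this number.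

The compounds shown leave open whether the gain belongs to chlorine in particular or would also appear with fluoro, bromo, methyl or methoxy at that place on the 4-carboxy-3-chlorophenyl group. They also leave open whether the same move would hold with a group other than the carboxylic acid on this ring, such as a tetrazole or an amide, or with a change to the saturated chain that carries the ring.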